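A few compounds are considered here, and "the series" means these few. Any claim that something is new, unique, unknown or untested is made for them only; others in the source may bear on it.

Measured compounds:
compound 1, `NC(=O)c1ncn2c(=O)n(-c3cccc4ccccc34)nnc12` — 0.0767 h
compound 2, `NC(=O)c1ncn2c(=O)n(-c3ccc([N+](=O)[O-])cc3)nnc12` — < 0.0167 h

In an ADME assay for pharmacokinetics (a lower number here means that the compound disappears faster, a higher number that the compound lasts longer), compound 1 gives 0.0767 h. Compound 2 reaches only the limit of this assay, < 0.0167 h, so where compound 2 stands on these numbers is known as a limit alone (the limit of < 0.0167 h in this assay, at which 1 of the 2 values shown sits). Compound 3, `NC(=O)c1ncn2c(=O)n(-c3ccccc3)nnc12`, is not yet measured in this assay. It differs from compound 2 by hydrogen in place of nitro on an aromatic carbon. The step of an at least 2.9-fold higher number from compound 2 to compound 3 (0.47 log units; beyond the scatter) is expected to run upward, toward a longer half-life, though its size rests on a single limit. For compound 3 the half-life is estimated at 0.05 h, expected between 0.015 h and 0.2 h.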

Compound 3, half-life: 0.383 h
For compound 3 the middle estimate is 7.7-fold (0.88 log units) below the measured one; the whole stated range lies below it.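

In this assay, hydrogen in place of nitro on an aromatic carbon, para to a large group, gives an at least 22-fold higher number from compound 2 to compound 3 (1.36 log units; beyond the scatter), so the group at this position bears strongly on the half-life. For the compounds shown here, the earlier compounds offered no pair differing in one place, and this is the first step that can be read here. On these data alone, its full size remains unknown, since compound 2 stands only at a limit: the limit of < 0.0167 h in this assay, at which 1 of the 3 values shown sits. As far as these compounds go, whether an amine or a chlorine at this carbon would give a half-life nearer that of compound 2 or compound 3 remains open. So does whether the short half-life is particular to nitro.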